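A few compounds are considered here, and "the series" means these few. Any claim that something is new, unique, unknown or untested is made for them only; others in the source may bear on it.

Measured so far in an assay on isolated protein with metabotropic glutamate receptor 5 (Rattus norvegicus) as the target; on this read-out higher numbers stand for an effect only at larger amounts of compound and lower numbers for an effect already at smaller amounts:
compound 1 `O=C(Nc1cc(-c2ccccc2)nn1-c1ccccc1)c1cccc(F)c1` gives 65 nM
compound 2 `O=C(Nc1cc(-c2ccccc2)nn1-c1ccccc1)c1ccsc1` gives 2900 nM
compound 3 `O=C(Nc1cc(-c2ccccc2)nn1-c1ccccc1)c1ccc(F)c(F)c1` gives 20 nM

Among these three numbers compound 1 stands second highest. Its nearest neighbour is compound 3, reached by a 3.3-fold lower number from compound 1 to compound 3 (0.51 log units; beyond the scatter); its furthest is compound 2, reached by a 45-fold higher number from compound 1 to compound 2 (1.65 log units; beyond the scatter). Compound 4 `O=C(Nc1cc(-c2ccccc2)nn1-c1ccccc1)c1cccc(Cl)c1` differs from compound 1 in one place: chloro in place of fluoro on an aromatic carbon. Going by the values given here, no measured step swaps one halogen for another, so the bearing of the known steps is indirect. The step from compound 1 to compound 2 shows that replacing the whole ring on the carbonyl carbon moves this assay a great deal, whereas the step from compound 1 to compound 3 shows that adding a single halogen to that ring moves it only modestly. A change of one halogen for another, in the same spot on the same ring, is expected to be smaller still, so the step from compound 1 to compound 4 is estimated to stay within the scatter, in either direction, as a 1.2-fold lower number from compound 1 to compound 4 (0.07 log units; within the scatter). Compound 4 is therefore expected to give about 55 nM, with a range from 18 nM to 170 nM.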

Compound 4, half-maximal effective concentration: 200 nM
For compound 4 the middle estimate is 3.6-fold (0.56 log units) below the measured one, outside the stated range (above it).
By their numbers in this assay, from the lowest: compound 3; then compound 1; then compound 4; then compound 2.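

In this assay, exchanging one halogen for another at this place is not a silent change: going from 3-fluorophenyl to 3-chlorophenyl gives a 3.1-fold higher number from compound 1 to compound 4 (0.49 log units; beyond the scatter) as a modest step, moving the opposite way from a 3.3-fold lower number from compound 1 to compound 3 (0.51 log units; beyond the scatter) on the same ring. Set against the other rings on the carbonyl, the 3-chlorophenyl compound falls in the middle, with a 10-fold higher number from compound 3 to compound 4 (1.00 log units; beyond the scatter) on one side and a 15-fold lower number from compound 2 to compound 4 (1.16 log units; beyond the scatter) on the other. Nothing available accounts for the difference between chloro and fluoro here.

From the compounds shown here alone, whether bromo, methyl or methoxy in the same place would give a number closer to that of compound 1 or that of compound 4 remains open. Also open, going by these compounds, is whether chloro combined with a second halogen on this ring would lower the number, as the added fluoro of compound 3 did.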